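A few compounds are considered here, and "the series" means these few. Any claim that something is new, unique, unknown or untested is made for them only; others in the source may bear on it.

Three compounds have been measured in an assay (Rattus norvegicus) for inhibition of Fatty-acid amide hydrolase 1 (Homo sapiens); a higher number here means a weaker inhibitor, a lower number a stronger inhibitor:
compound 1 `COc1ccccc1-c1cnc(C(=O)CCCCCCc2ccccc2)o1` gives 400 nM;
compound 2 `N#Cc1ccccc1-c1cnc(C(=O)CCCCCCc2ccccc2)o1` gives 130 nM;
compound 3 `N#Cc1cccc(-c2cnc(C(=O)CCCCCCc3ccccc3)o2)c1` gives 15 nM.

Compound 2 stands second highest of the three: a 3.1-fold lower number from compound 1 to compound 2 (0.49 log units; beyond the scatter), and an 8.7-fold lower number from compound 2 to compound 3 (0.94 log units; beyond the scatter). Compound 4 `O=C(CCCCCCc1ccccc1)c1ncc(-c2ncccn2)o1` differs from compound 2 in one place: pyrimidin-2-yl in place of 2-cyanophenyl on an aromatic carbon. Going by the values given here, no measured step swaps the whole ring for a six-membered aromatic ring with 2 hetero atoms; the nearest guides are the exchange of one group, a 3.1-fold lower number from compound 1 to compound 2 (0.49 log units; beyond the scatter), and the shift of a group within the ring, an 8.7-fold lower number from compound 2 to compound 3 (0.94 log units; beyond the scatter). Because the new ring also drops the cyano group that marked a 3.1-fold lower number from compound 1 to compound 2 (0.49 log units; beyond the scatter), a change of roughly that size in either direction is plausible, so a number near that of compound 2 is expected. Compound 4 is estimated at 300 nM, between 60 nM and 1500 nM, an expected step of a 2.3-fold higher number from compound 2 to compound 4 (0.36 log units; beyond the scatter).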

Compound 4, inhibition constant: 5.3 nM
For compound 4 the middle estimate is 57-fold (1.75 log units) above the measured one; the measured number lies below the stated range.
By their numbers in this assay, from the lowest: compound 4; then compound 3; then compound 2; then compound 1.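

In this assay, this position accepts a ring that is not a phenyl at all: pyrimidin-2-yl brings the number down across all three comparisons (a 25-fold lower number from compound 2 to compound 4 (1.39 log units; beyond the scatter)), (a 2.8-fold lower number from compound 3 to compound 4 (0.45 log units; beyond the scatter)) and (a 75-fold lower number from compound 1 to compound 4 (1.88 log units; beyond the scatter)). Compound 4 is therefore the strongest inhibitor of the four, and neither a nitrile nor a methoxy group is needed for strength here. No measurement shown accounts for this gain.

On these data alone, the effect of the ring nitrogens alone remains open, which an unsubstituted phenyl could test. Also open, as far as these compounds go, is what an amine or a carboxylic acid on the pyrimidine ring would do.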